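A Hydroxy Group Enters a Weakly Cytotoxic Series

The compounds below may be only part of what the source reports. "The series", "measured", "known", "first", "only" and "open" are said of these compounds alone.

Compound 1 `Fc1cccc(-c2nc(Nc3ccccc3)c3cc(F)ccc3n2)c1` is the reference point here. In a functional assay on HL-60 cells (Homo sapiens) for cytotoxicity, read by MTT assay, with a stated time of 48 h (on this read-out higher numbers stand for weaker inhibition and lower numbers for stronger inhibition), compound 1 gives 48300 nM, the highest of the two numbers shown, though its nearest neighbour is compound 3 `Fc1cccc(-c2nc(Nc3ccc(Cl)cc3)c3cc(F)ccc3n2)c1`, which in this assay gives 45700 nM. Compound 2 `Fc1cccc(-c2nc(Nc3ccccc3F)c3cc(F)ccc3n2)c1` reaches only a limit of this assay, namely > 50000 nM, so no number is known for it. The unmeasured compound 4 `Oc1ccccc1Nc1nc(-c2cccc(F)c2)nc2ccc(F)cc12` differs from compound 1 by hydroxy in place of hydrogen on an aromatic carbon. For the measured compounds named here, two measured steps bear on this change: an at least 1.0-fold higher number from compound 1 to compound 2 (0.01 log units; that floor lies within the scatter) and a 1.1-fold lower number from compound 1 to compound 3 (0.02 log units; within the scatter). Both put fluoro or chloro in place of a hydrogen on the anilino ring and neither moved the number beyond the scatter, with compound 2 stopping at the limit of > 50000 nM in this assay, at which 1 of the 3 values shown sits. A hydroxy in place of hydrogen at the same kind of site is therefore expected to give no step beyond the scatter, a 1.0-fold higher number from compound 1 to compound 4 (0.02 log units; within the scatter). For compound 4 the estimate in this assay is 50000 nM, with a range from 20000 nM to 120000 nM, and a real chance that only a limit is reported.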

Compound 4, half-maximal inhibitory concentration: 44400 nM
Compound 4: the middle estimate sits 1.1-fold (0.05 log units) above what was measured; the measured number falls inside the stated range.
By their numbers in this assay, from the lowest: compounds 4, 3 and 1 (each within the scatter of the next). At a limit, above all of these: compound 2.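

Hydroxy adds a hydrogen-bond donor and acceptor to the anilino ring, yet in this assay it gives a 1.1-fold lower number from compound 1 to compound 4 (0.04 log units; within the scatter), so this new kind of group leaves the number as unmoved as the halogens did. Against the chloro analogue the result is a 1.0-fold lower number from compound 3 to compound 4 (0.01 log units; within the scatter), so the 2-hydroxyphenyl and 4-chlorophenyl groups cannot be told apart here. Against the fluoro analogue the result is an at least 1.1-fold lower number from compound 2 to compound 4 (0.05 log units; that floor lies within the scatter), but compound 2 gives a limit and not a number, so this step is only a floor: the limit of > 50000 nM in this assay, at which 1 of the 4 values shown sits.

From the compounds shown here alone, it remains open whether an amine or a carboxylic acid in place of the hydroxy would move the number beyond the scatter. Also open, going by these compounds, is whether any change to the shared core, rather than to the anilino ring, would do so.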